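This account rests on a few compounds, and the source may have more. Where it says the series, first, only, none or still open, it means among the compounds named here.

Measured so far:
- compound 1, `O=C(COc1cccc2ccccc12)N/N=C/c1ccc(O)cc1`: 26.5 ug/mL
- compound 2, `O=C(COc1cccc2ccccc12)N/N=C/c1ccccc1Cl`: 56.2 ug/mL
- compound 3, `O=C(COc1cccc2ccccc12)N/N=C/C=C/c1ccccc1`: 82.7 ug/mL

In an ADME assay on MT4 cells (Homo sapiens) for cytotoxicity, read by MTT assay, with a stated time of 4 days (a lower number here means that less compound is tolerated, a higher number that more compound is tolerated), compound 3 gives the highest of the three numbers. Its nearest neighbour is compound 2, and the step of a 1.5-fold higher number from compound 2 to compound 3 (0.17 log units; within the scatter) lies within the scatter, so the two cannot be ranked against each other. The step of a 3.1-fold higher number from compound 1 to compound 3 (0.49 log units; beyond the scatter) is beyond the scatter, so compound 3 is clearly tolerated better than compound 1.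

Compound 4, `O=C(COc1cccc2ccccc12)N/N=C/c1ccc(Br)cc1`, differs from compound 3 in one place: 4-bromophenyl in place of 2-phenylethenyl on a carbon with a double bond to nitrogen. Within the data shown here, no measured step swaps exactly these two groups. Among the measured compounds shown here, the steps that bear on it are a 2.1-fold higher number from compound 1 to compound 2 (0.33 log units; beyond the scatter) and a 3.1-fold higher number from compound 1 to compound 3 (0.49 log units; beyond the scatter), both replacing 4-hydroxyphenyl at the same carbon, and a 1.5-fold higher number from compound 2 to compound 3 (0.17 log units; within the scatter), which shows that a phenyl bearing a chlorine and 2-phenylethenyl sit within the scatter of each other. A 4-bromophenyl is expected to behave much like the 2-chlorophenyl of compound 2, so in this assay a small downward step or none beyond the scatter is expected. Compound 4 is therefore estimated at 55 ug/mL, within a range from 28 ug/mL to 110 ug/mL. The expected step is a 1.5-fold lower number from compound 3 to compound 4 (0.18 log units; within the scatter).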

Compound 4, half-maximal cytotoxic concentration: 106 ug/mL
Compound 4: middle estimate off by 1.9-fold (0.28 log units), on the low side; the measured number falls inside the stated range.
By their numbers in this assay, from the lowest: compound 1; then compounds 2, 3 and 4 (each within the scatter of the next).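

In this assay, a 1.3-fold higher number from compound 3 to compound 4 (0.11 log units; within the scatter) and a 1.9-fold higher number from compound 2 to compound 4 (0.28 log units; within the scatter) both lie within the scatter, so the 4-bromophenyl, 2-chlorophenyl and 2-phenylethenyl groups on this carbon cannot be ranked against one another. The new compound also gives the largest step in the series, since bromo in place of hydroxy on the aromatic carbon brings a 4.0-fold higher number from compound 1 to compound 4 (0.60 log units; beyond the scatter) and leaves compound 1 as the one clearly less tolerated of this pair. No measurement shown here gives a reason for that difference.

Going by these compounds, whether an amine or a carboxylic acid on that aromatic carbon would stay near the number of compound 1 or near that of compound 4 remains open. So does the effect of moving a single halogen around the ring, as compound 2 and compound 4 differ in both the halogen and its place.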